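Demethylation of the methoxy arm on two urea variants

This account rests on a few compounds, and the source may have more. Where it says the series, first, only, none or still open, it means among the compounds named here.

Measured so far in a functional assay on NCI-H460 cells (Homo sapiens) for inhibition, read by sulforhodamine B assay, with a stated time of 48 h; on this read-out lower numbers stand for higher toxicity in this test and higher numbers for lower toxicity in this test:
compound 1 `COc1cc(-c2nn(-c3cccc(NC(=O)Nc4ccc(Cl)c(Cl)c4)c3)cc2-c2ccncc2)ccc1Cl`, at a limit of the assay: > 50000 nM
compound 2 `O=C(Nc1cccc(-n2cc(-c3ccncc3)c(-c3ccc(Cl)c(O)c3)n2)c1)Nc1ccc(Cl)c(Cl)c1`: 24200 nM
compound 3 `COc1cc(-c2nn(-c3cccc(NC(=O)Nc4ccc(Cl)c(C(F)(F)F)c4)c3)cc2-c2ccncc2)ccc1Cl`, at a limit of the assay: > 32500 nM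

Compound 2 differs from compound 1 by hydrogen in place of methyl on an oxygen on an aromatic ring; that step is an at least 2.0-fold lower number from compound 1 to compound 2 (0.31 log units; beyond the scatter). The two cores differ by trifluoromethyl in place of chloro on an aromatic carbon; the step is a step that the two limits leave unreadable from compound 1 to compound 3. Compound 1 stands at the limit of > 50000 nM in this assay, at which 1 of the 3 values shown sits. Compound 3 stands at the limit of > 32500 nM in this assay, at which 1 of the 3 values shown sits.

Compound 4 `O=C(Nc1cccc(-n2cc(-c3ccncc3)c(-c3ccc(Cl)c(O)c3)n2)c1)Nc1ccc(Cl)c(C(F)(F)F)c1` is not yet measured. It differs from compound 3 by hydrogen in place of methyl on an oxygen on an aromatic ring, the same change made from compound 1 to compound 2, at the same place. From compound 3 to compound 4 a step of about an at least 1.4-fold lower number from compound 3 to compound 4 (0.16 log units; that floor lies within the scatter) in this assay is expected, resting on the step of an at least 2.0-fold lower number from compound 1 to compound 2 (0.31 log units; beyond the scatter), whose size is itself only a lower bound. Compound 4 is thus estimated at 22000 nM, between 7000 nM and 60000 nM.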

Compound 4, concentration lethal to 50% of the cells: > 32500 nM
Compound 4 ended at the assay's limit; the forecaster's own chance of this, stated with the estimate: 35%; middle value at least 1.4-fold (0.16 log units) away from the limit.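

In this assay compound 4 gives > 32500 nM, which is a limit of the assay and not a number. The methoxy to hydroxy change cannot be read on the trifluoromethyl core because compound 3 and compound 4 stand at the same limit: the limit of > 32500 nM in this assay, at which 2 of the 4 values shown sit. Among these compounds, the earlier result, an at least 2.0-fold lower number from compound 1 to compound 2 (0.31 log units; beyond the scatter), is therefore neither confirmed nor contradicted on this second core, and the one readable new step, an at least 1.3-fold higher number from compound 2 to compound 4 (0.12 log units; that floor lies within the scatter), concerns trifluoromethyl in place of chloro among the hydroxy compounds, not the transfer itself.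

Still open, from the compounds shown here alone, is how far compound 4 lies past its limit. Also open, going by these compounds, is whether an amine or a carboxylic acid in place of the hydroxy would give a value on either core.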